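The source may report more compounds than this note shows. Statements on the series, on what has been measured and on what is new or still open speak of the compounds shown alone.

Two compounds of this series carry measured numbers in a functional assay on PC-3 cells (Homo sapiens) for cytotoxicity, read by MTT assay, with a stated time of 72 h; a lower number here means a stronger inhibitor, a higher number a weaker inhibitor. Compound 1 `CCCCOCNc1n[n+]([O-])c2ccccc2[n+]1[O-]` gives 14700 nM in this assay, and compound 2 `COCNc1n[n+]([O-])c2ccccc2[n+]1[O-]` gives 7510 nM. Within the data shown here, the only step between them, a 2.0-fold lower number from compound 1 to compound 2 (0.29 log units; within the scatter), does not rise above the scatter, so compound 2 stands at one end of a pair whose two numbers cannot be told apart.

Compound 3 `[O-][n+]1nc(NCOC2CCCCC2)[n+]([O-])c2ccccc21` has not yet been measured in this assay. It differs from compound 2 by cyclohexyl in place of methyl on an oxygen on a saturated carbon. Among the measured compounds shown here, the one step that bears on a change at this oxygen, a 2.0-fold lower number from compound 1 to compound 2 (0.29 log units; within the scatter), swapped propyl for hydrogen on the chain carbon bound to the oxygen and stayed within the scatter; nothing else touches this position, and no measured step involves a ring. On that basis no step beyond the scatter is expected in this assay for compound 3, with the number estimated as a 1.2-fold higher number from compound 2 to compound 3 (0.08 log units; within the scatter). Compound 3 is therefore expected near 9000 nM, somewhere between 3000 nM and 30000 nM.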

Compound 3, half-maximal inhibitory concentration: 3250 nM
Compound 3: the middle estimate sits 2.8-fold (0.44 log units) above what was measured; low and high end bracket the measured number.
By their numbers in this assay, from the lowest: compound 3; then compounds 2 and 1 (each within the scatter of the next).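

Among these compounds, on the oxygen on a saturated carbon, cyclohexyl gives the first steps beyond the scatter in this assay, with a 2.3-fold lower number from compound 2 to compound 3 (0.36 log units; beyond the scatter) for cyclohexyl in place of methyl and a 4.5-fold lower number from compound 1 to compound 3 (0.66 log units; beyond the scatter) for cyclohexyl in place of butyl. Methyl and butyl at this position could not be told apart, whereas cyclohexyl separates compound 3 from both, though each step remains modest. No measurement available here speaks to the reason for this separation.

The compounds shown leave open whether the ring itself matters or whether any larger carbon group on this oxygen would read the same way. A phenyl, a branched chain such as tert-butyl or a cyclohexyl carrying an amine would help separate those readings in this assay.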